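Methoxy for fluoro on the core of compound 1

The compounds below may be only part of what the source reports. "The series", "measured", "known", "first", "only" and "open" are said of these compounds alone.

Measured so far:
compound 1, `CC(C)n1c(=O)n(C(=O)NCCN2CCN(C)CC2)c2cc(F)ccc21` — 0.67
compound 2, `C=CCn1c(=O)n(C(=O)NCCN2CCN(C)CC2)c2ccccc21` — 0.63
compound 3, `CC(C)n1c(=O)n(C(=O)NCCN2CCN(C)CC2)c2cc(F)c(N)cc21` — < 0.3

In a functional assay for agonist activity at 5-hydroxytryptamine receptor 4 (Cavia porcellus) (a lower number here means a smaller maximal response, a higher number a larger maximal response), compound 1 gives 0.67, the highest of the two plain numbers shown. Compound 2 gives 0.63, which lies within the scatter of compound 1, so no order between the two can be claimed. Compound 3 gives only a limit, < 0.3, not a number.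

Among the compounds with values here, the one single-point step with a known size is a number at least 0.37 lower from compound 1 to compound 3 (beyond the scatter); with the limit of < 0.3 in this assay, at which 1 of the 3 values shown sits, it shows that this assay can report a floor rather than a value.

Compound 4, `COc1ccc2c(c1)n(C(=O)NCCN1CCN(C)CC1)c(=O)n2C(C)C`, has not yet been measured in this assay. It differs from compound 1 by methoxy in place of fluoro on an aromatic carbon. Within the data shown here, no measured step exchanges fluoro for methoxy, so the step from compound 1 to compound 3 bears on it only in that a change at an aromatic carbon of the core can move the maximal response a great deal. A methoxy in place of fluoro is expected to give a step of modest size, if any, most likely downward, that is a number 0.12 lower from compound 1 to compound 4 (beyond the scatter). Compound 4 is therefore estimated at 0.55, with a range from 0.35 to 0.75.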

Compound 4, intrinsic activity: the largest response reached, as a fraction of the reference agonist's: < 0.3
Compound 4 gave a limit, no number (the forecaster's own chance of this, stated with the estimate: 15%); middle value at least 0.25 from the limit.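

In this assay compound 4 gives < 0.3, which is a limit and not a number. The change at the aromatic carbon that carries fluoro in compound 1 reads as a number at least 0.37 lower from compound 1 to compound 4 (beyond the scatter), so this carbon is now shown to be sensitive in its own right: methoxy in place of fluoro costs a large part of the maximal response, whereas the earlier step concerned amino on a different aromatic carbon with the fluoro kept. The full size of this step remains unknown, and the limit now recurs across the series: the limit of < 0.3 in this assay, at which 2 of the 4 values shown sit.

Whether the loss belongs to methoxy alone or to any replacement of fluoro at this carbon stays open, since the compounds shown hold no chloro, methyl, hydroxy or plain hydrogen there on the otherwise unchanged core of compound 1. On these data alone, it is also open whether a longer chain such as ethoxy would behave like methoxy, and the true maximal response of compound 4 cannot be read from this assay's result.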